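Lengthening the chain on compound 3

The source may report more compounds than this note shows. Statements on the series, on what has been measured and on what is new or still open speak of the compounds shown alone.

Of the compounds shown here, three sharing one core have been measured in a functional assay on WM164 cells (Homo sapiens) for antiproliferative activity, read by sulforhodamine B assay, with a stated time of 48 h; a lower number here means a stronger inhibitor, a higher number a weaker inhibitor. Compound 1 (`CCCCCCCCCCNC(=O)[C@@H]1CSC(c2ccc(OC)c(OC)c2)N1`) gives 6100 nM, compound 2 (`CCCCCCCCCCCCNC(=O)[C@@H]1CSC(c2ccc(OC)c(OC)c2)N1`) gives 1600 nM and compound 3 (`CCCCCCCCCCCCNC(=O)[C@@H]1CSC(c2ccc(NC(C)=O)cc2)N1`) gives 1200 nM. Compound 3 therefore shares the low end of these numbers with compound 2, and compound 1 stands further off. The exchange of 3,4-dimethoxyphenyl for 4-acetamidophenyl on a saturated ring carbon moved little: a 1.3-fold lower number from compound 2 to compound 3 (0.12 log units; within the scatter).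

Compound 4 (`CCCCCCCCCCCCCCCCNC(=O)[C@@H]1CSC(c2ccc(NC(C)=O)cc2)N1`) keeps the 4-acetamidophenyl group and extends the chain: butyl in place of hydrogen on a saturated chain carbon, ten or more bonds along the chain from an amide-type nitrogen. Going by the values given here, the closest precedent is the change of the same kind at the same place, with ethyl entering instead of butyl and with 3,4-dimethoxyphenyl on the ring: a 3.8-fold lower number from compound 1 to compound 2 (0.58 log units; beyond the scatter). Among the compounds with values here, that single step is the only evidence on chain length, and no measured compound shows whether the trend continues at this greater length or carries over to the 4-acetamidophenyl compounds. A further modest fall in this assay is expected, though it may not clear the scatter. The expected step is a 2.0-fold lower number from compound 3 to compound 4 (0.30 log units; within the scatter). For compound 4 the estimate is 600 nM, with an expected range from 200 nM to 1800 nM.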

Compound 4, half-maximal inhibitory concentration: 600 nM
Compound 4: middle estimate and measured number agree at the digits printed, within the range that was stated.
By their numbers in this assay, from the lowest: compounds 4, 3 and 2 (each within the scatter of the next, the first and the last beyond it); then compound 1.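

With the 4-acetamidophenyl group on the ring, butyl in place of hydrogen on a saturated chain carbon, ten or more bonds along the chain from an amide-type nitrogen, gives a step in this assay that stays within the scatter (a 2.0-fold lower number from compound 3 to compound 4 (0.30 log units; within the scatter)). Going by these compounds alone, the position therefore accepts this longer chain on a 4-acetamidophenyl compound without a step beyond the scatter, whereas the only earlier chain step, ethyl entering on a 3,4-dimethoxyphenyl compound, lay beyond it (a 3.8-fold lower number from compound 1 to compound 2 (0.58 log units; beyond the scatter)). No measured property on hand bears on this result.

The two chain steps differ both in the group entering and in the group on the ring, so a butyl step on a 3,4-dimethoxyphenyl compound would be needed to tell these two differences apart. Also open, on these data alone, is how this assay responds to a still longer chain at this place, or to a chain of the same length ending in an amine or a carboxylic acid.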